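A few compounds are considered here, and "the series" means these few. Any claim that something is new, unique, unknown or untested is made for them only; others in the source may bear on it.

For the measured compounds named here, in a functional assay on MCF7 cells (Homo sapiens) for inhibition, read by sulforhodamine B assay, with a stated time of 48 h (on this read-out higher numbers stand for weaker inhibition of growth and lower numbers for stronger inhibition of growth), three compounds have numbers so far. Compound 1 `N#CCC1=NN=C(c2ccc(Br)cc2)C(CC(=O)c2ccc(Br)cc2)O1` gives 30400 nM and compound 2 `N#CCC1=NN=C(c2ccc(Br)cc2)C(CC(=O)c2ccc([N+](=O)[O-])cc2)O1` gives 32000 nM. Compound 3 `N#CCC(=O)N/N=C(/CBr)c1ccc([N+](=O)[O-])cc1` gives 18400 nM, though it does not carry the core of the other two. Compound 2 lies within the scatter of both others, so these three values set no order among them.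

Compound 4 `N#CCC1=NN=C(c2ccc([N+](=O)[O-])cc2)C(CC(=O)c2ccc([N+](=O)[O-])cc2)O1` differs from compound 2 by one change: nitro in place of bromo on an aromatic carbon. In words, this is nitro in place of bromo on an aromatic carbon, 4-bromophenyl to 4-nitrophenyl. Going by the values given here, only one measured step is of the same kind, a 1.1-fold higher number from compound 1 to compound 2 (0.02 log units; within the scatter). Among the compounds with values here, that step was made on the other aromatic ring, so it is a guide and not a direct precedent, and no measurement yet covers this ring. On that single step, no shift beyond the scatter is expected in this assay. The estimated 1.1-fold lower number from compound 2 to compound 4 (0.03 log units; within the scatter) is accordingly small. Compound 4 is expected at 30000 nM, with an estimated range of 15000 nM to 60000 nM.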

Compound 4, concentration for 50% growth inhibition: 1600 nM
Beside the measured number, compound 4's estimate is 19-fold (1.27 log units) above it; the whole stated range lies above it.
By their numbers in this assay, from the lowest: compound 4; then compounds 3, 1 and 2 (each within the scatter of the next).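

In this assay, for the compounds shown here, the change from 4-bromophenyl to 4-nitrophenyl gives a 20-fold lower number from compound 2 to compound 4 (1.30 log units; beyond the scatter) and is the first step beyond the scatter. The same exchange of bromo for nitro on the other aromatic ring gave only a 1.1-fold higher number from compound 1 to compound 2 (0.02 log units; within the scatter), so across these two steps the effect of the exchange is not the same on the two rings. This position, para to a large group on the ring attached to the shared core, is therefore sensitive to the group it carries, at least when the other ring bears nitro.

On these data alone, whether the large step needs that second nitro, and whether an amine or a carboxylic acid in the same place would give a similar number, remains open. No measurement shown here explains the size of this step.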